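This account rests on a few compounds, and the source may have more. Where it says the series, first, only, none or still open, it means among the compounds named here.

Of the compounds shown here, three have so far been measured in a functional assay on HEK293 cells for agonist activity at probable G-protein coupled receptor 27 (Homo sapiens), read by a luciferase reporter and beta-arrestin recruitment, with a stated time of 10 min (on this read-out lower numbers stand for an effect already at smaller amounts and higher numbers for an effect only at larger amounts of compound), and a fourth is still to come.

Compound 1 `O=C(Nc1ccc(S(=O)(=O)Nc2ccccc2)cc1)c1cc2ccccc2oc1=O` gives 7760 nM in this assay. Like compound 1, compound 3 `O=C(Nc1ccc(S(=O)(=O)Nc2ccccc2)cc1)c1cc(F)c(Cl)cc1F` carries a phenyl group on its sulfonamide nitrogen, and compound 3 gives 141 nM. Compound 2 `O=C(NS(=O)(=O)c1ccc(NC(=O)c2ccc(Cl)cc2Cl)cc1)c1ccccc1` is built differently: its sulfonamide nitrogen bears a benzoyl group rather than a ring. For compound 2 this assay reports only a limit, > 100000 nM, not a number. Compound 2 therefore stands at the top end of what the read-out can show, at the limit of > 100000 nM in this assay, at which 1 of the 3 values shown sits, while compounds 1 and 3 both sit well inside the measurable range.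

The unmeasured compound 4 `O=C(Nc1ccc(S(=O)(=O)Nc2ncccn2)cc1)c1ccc(Cl)cc1Cl` differs from compound 2 in one place: pyrimidin-2-yl in place of benzoyl on a sulfonamide nitrogen. After this change the sulfonamide nitrogen once again carries an aromatic ring, as in compounds 1 and 3, although now one with two hetero atoms, and the rest of the molecule is unchanged.

For the measured compounds named here, since compound 2 gives only a limit, no measured step starts from it. Still, compounds 1 and 3, which both carry a ring on that nitrogen, give numbers, so the step from compound 2 to compound 4 is expected to be large and towards lower numbers, roughly an at least 40-fold lower number from compound 2 to compound 4 (1.60 log units; beyond the scatter). Compound 4 is estimated at 2500 nM in this assay, within a range from 300 nM to 25000 nM.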

Compound 4, half-maximal effective concentration: > 100000 nM
Compound 4: only a limit was reported (the forecaster's own chance of this, stated with the estimate: 25%); middle value at least 40-fold (1.60 log units) away from the limit.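

Compound 2 and compound 4 both give only a limit of the read-out, not a number, so the size of the step between them cannot be read: the limit of > 100000 nM in this assay, at which 2 of the 4 values shown sit.

On these data alone, what stays open is how far each compound lies past that limit, and whether pyrimidin-2-yl in place of benzoyl on a sulfonamide nitrogen changes the response at all.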